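The source may report more compounds than this note shows. Statements on the series, on what has been measured and on what is new or still open speak of the compounds shown alone.

Measured compounds:
Compound 1, `CN(C)Cc1ccc2nc(NC(=O)N/N=C/c3ccccn3)sc2c1`: > 40000 nM
Compound 2, `CC1CCN(Cc2ccc3nc(NC(=O)N/N=C/c4ccccn4)sc3c2)CC1`: > 40000 nM
Compound 3, `CN(C)Cc1ccc(NC(=O)N/N=C/c2ccccn2)cc1`: > 40000 nM

All three were tested in a functional assay on MCF7 cells (Homo sapiens) for antiproliferative activity, read by CCK-8 assay, with a stated time of 24 h; on this read-out higher numbers stand for weaker inhibition and lower numbers for stronger inhibition. In this assay compound 1 gives > 40000 nM, which is a limit of the assay rather than a number. Compound 2 likewise returns > 40000 nM in this assay, again a limit. Compound 3 stands at > 40000 nM in this assay, also a limit. Among the measured compounds shown here, the only change from compound 1 to compound 2 is 4-methylpiperidin-1-yl in place of dimethylamino on a saturated chain carbon bound to an aromatic carbon. The step that the two limits leave unreadable from compound 1 to compound 2 cannot be read, because both ends sit at the limit of > 40000 nM in this assay, at which 3 of the 3 values shown sit. Compound 1 and compound 3 are built on different cores, and the difference between the two cores is not broken down here.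

Compound 4, `CC1CCN(Cc2ccc(NC(=O)N/N=C/c3ccccn3)cc2)CC1`, has not yet been measured. It differs from compound 3 by 4-methylpiperidin-1-yl in place of dimethylamino on a saturated chain carbon bound to an aromatic carbon, the same change that turns compound 1 into compound 2, at the same place. For the measured compounds named here, because the limit of > 40000 nM in this assay, at which 3 of the 3 values shown sit, holds every compound measured so far, there is no sign in these data that this change moves the read-out at all, and the expected step that the limit leaves unreadable from compound 3 to compound 4 is essentially none. Compound 4 is therefore estimated at 60000 nM in this assay, with a likely span from 20000 nM to 200000 nM, and the assay is expected most often to report only a limit again.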

Compound 4, half-maximal inhibitory concentration: > 40000 nM
Compound 4: a limit, no number; the forecaster's own chance of this, stated with the estimate: 85%; the middle value does not contradict the limit.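

In this assay compound 4 gives > 40000 nM, which is a limit and not a number. No step can be read from compound 3 to compound 4, because both ends sit at a limit: the limit of > 40000 nM in this assay, at which 4 of the 4 values shown sit. The compounds shown leave open whether 4-methylpiperidin-1-yl in place of dimethylamino, or the difference between the two cores, changes this read-out at all.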